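A Smaller Benzyl Group After Removing Tert-Butyl

A few compounds are considered here, and "the series" means these few. Any claim that something is new, unique, unknown or untested is made for them only; others in the source may bear on it.

Three sulfonamides have been measured in a functional assay on MIA PaCa-2 cells (Homo sapiens) for inhibition, read by MTT assay, with a stated time of 72 h; on this read-out lower numbers stand for stronger inhibition of growth and higher numbers for weaker inhibition of growth. Compound 1 `O=S(=O)(NCCNCc1cccc2ccccc12)c1cc(C(F)(F)F)cc(C(F)(F)F)c1` gives 26000 nM. Compound 2 `CC(C)(C)c1ccc(CNCCCNS(=O)(=O)c2cc(C(F)(F)F)cc(C(F)(F)F)c2)cc1` gives 2300 nM. Compound 3 `O=S(=O)(NCCNCc1ccc(-c2ccccc2)cc1)c1cc(C(F)(F)F)cc(C(F)(F)F)c1` gives 2700 nM. Compound 2 and compound 3 stand within the scatter of each other, while compound 1 stands beyond the scatter above both. Compound 4 `O=S(=O)(NCCCNCc1ccccc1)c1cc(C(F)(F)F)cc(C(F)(F)F)c1` differs from compound 2 by hydrogen in place of tert-butyl on an aromatic carbon, so compound 4 carries a plain benzyl group on the same chain. For the measured compounds named here, no measured pair isolates this change. Compound 4 is expected to give a weaker, higher number than compound 2, with a step from compound 2 to compound 4 of a 4.3-fold higher number from compound 2 to compound 4 (0.64 log units; beyond the scatter), beyond the scatter, partly because compound 1 with a smaller aromatic group gives 26000 nM. Compound 4 is estimated at 10000 nM, within 3500 nM to 30000 nM.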

Compound 4, concentration for 50% growth inhibition: 11000 nM
Beside the measured number, compound 4's estimate is 1.1-fold (0.04 log units) below it; low and high end bracket the measured number.
By their numbers in this assay, from the lowest: compounds 2 and 3 (each within the scatter of the next); then compound 4; then compound 1.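

In this assay, for the compounds shown here, the only single-place comparison in this set is a 4.8-fold higher number from compound 2 to compound 4 (0.68 log units; beyond the scatter), so replacing tert-butyl with hydrogen on this aromatic carbon weakens growth inhibition by more than the scatter. The earlier compounds shown here differed in more than one place and could not separate this substituent from the rest of the structure. Nothing measured here explains the loss.

The compounds shown leave open whether a methyl, chlorine or methoxy group at this aromatic carbon would give a number closer to that of compound 2 or to that of compound 4.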